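Sulfamoylphenyl position change on the benzylated core

The compounds below may be only part of what the source reports. "The series", "measured", "known", "first", "only" and "open" are said of these compounds alone.

Measured compounds in a functional assay on Caco-2 cells (Homo sapiens) for antiproliferative activity, read by MTT assay; a lower number here means a stronger inhibitor, a higher number a weaker inhibitor:
compound 1 `NS(=O)(=O)c1cccc(/N=C2\NC(=O)/C(=C3/C(=O)Nc4ccccc43)S2)c1` gives 12100 nM
compound 2 `NS(=O)(=O)c1ccc(/N=C2\NC(=O)/C(=C3/C(=O)N(Cc4ccccc4)c4ccccc43)S2)cc1` gives > 200000 nM
compound 3 `CN1C(=O)/C(=C2\S/C(=N/c3ccc(S(N)(=O)=O)cc3)NC2=O)c2ccccc21` gives 163000 nM

Compound 2 stands at the top of the series in this assay: its value is a limit of the assay, not a number, and among the three values shown it is the one that the limit of > 200000 nM in this assay, at which 1 of the 3 values shown sits, describes. Compound 4 `NS(=O)(=O)c1cccc(/N=C2\NC(=O)/C(=C3/C(=O)N(Cc4ccccc4)c4ccccc43)S2)c1` differs from compound 2 by 3-sulfamoylphenyl in place of 4-sulfamoylphenyl on a double-bonded nitrogen. Within the data shown here, no measured step changes the position of the sulfamoyl group on this core, so the bearing of the measured data is indirect. Among the measured compounds shown here, the one measured step, an at least 1.2-fold lower number from compound 2 to compound 3 (0.08 log units; that floor lies within the scatter), concerns the group on the amide-type nitrogen, not the sulfamoylphenyl, and its size sits within the scatter. For the measured compounds named here, compound 1, which carries the 3-sulfamoylphenyl with hydrogen on the amide-type nitrogen, shows a lower number than compound 3, which carries the 4-sulfamoylphenyl with methyl there, but the two differ in two places and no step is given between them. Given the limit at compound 2, the expected step of an at least 2.2-fold lower number from compound 2 to compound 4 (0.34 log units; beyond the scatter) is a lowering into the measurable range, with wide uncertainty. Compound 4 is estimated at 90000 nM, within 15000 nM to 400000 nM.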

Compound 4, half-maximal inhibitory concentration: 103000 nM
Compound 4: the middle estimate sits 1.1-fold (0.06 log units) below what was measured, within the range that was stated.
By their numbers in this assay, from the lowest: compound 1; then compounds 4 and 3 (each within the scatter of the next). At a limit, above all of these: compound 2.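

The change from 4-sulfamoylphenyl to 3-sulfamoylphenyl on a double-bonded nitrogen now has its own step on the benzylated core, in this assay: an at least 1.9-fold lower number from compound 2 to compound 4 (0.28 log units; that floor lies within the scatter) gives only a floor, and nothing larger can be claimed from it. Compound 2 stands at a limit of the assay, not at a number: the limit of > 200000 nM in this assay, at which 1 of the 4 values shown sits. Among these compounds, with 3-sulfamoylphenyl held in place, benzyl in place of hydrogen on the amide-type nitrogen gives a step beyond the scatter, which the earlier compounds did not provide: an 8.5-fold higher number from compound 1 to compound 4 (0.93 log units; beyond the scatter).

Going by these compounds, the size of the position effect remains unknown on the benzylated core, and its direction and size remain unknown with hydrogen on the amide-type nitrogen. Also open, on these data alone, is where a longer chain or a carboxylic acid in place of benzyl on that nitrogen would fall.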